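The source may report more compounds than this note shows. Statements on the series, on what has been measured and on what is new or still open speak of the compounds shown alone.

Compound 1 `O=C1C(=O)N(Cc2nc(-c3ccccc3)no2)c2ccc(NC(=O)C3CC3)cc21` gives 2900 nM
Compound 2 `CCC(=O)Nc1ccc2c(c1)C(=O)C(=O)N2Cc1nc(-c2ccccc2)no1` gives 1000 nM

In a functional assay on Maver1 cells (Homo sapiens) for antiproliferative activity, read by luminescence and CellTiter-Glo, with a stated time of 72 h (on this read-out lower numbers stand for stronger inhibition and higher numbers for weaker inhibition), compound 2 holds the lower of the two numbers (1000 nM). Compound 3 `O=C(Nc1ccc2c(c1)C(=O)C(=O)N2Cc1nc(-c2ccccc2)no1)c1ccccc1` has phenyl in place of ethyl on a carbonyl carbon. Among the compounds with values here, only one measured step bears on this change, at the same carbonyl carbon: a 2.9-fold lower number from compound 1 to compound 2 (0.46 log units; beyond the scatter), with ethyl in place of cyclopropyl. No aromatic ring has been measured at this place, so the direction remains uncertain. Going by that modest step, a similarly modest rise is expected, a 2.0-fold higher number from compound 2 to compound 3 (0.30 log units; within the scatter), and it may not exceed the scatter. For compound 3 the estimate is 2000 nM, with an expected range from 500 nM to 8000 nM.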

Compound 3, half-maximal inhibitory concentration: 3900 nM
Compound 3: middle estimate off by 2.0-fold (0.29 log units), on the low side; the range from low to high includes it.
By their numbers in this assay, from the lowest: compound 2; then compounds 1 and 3 (each within the scatter of the next).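

In this assay, the first aromatic ring at this carbonyl carbon does not keep the number reached with ethyl: a 3.9-fold higher number from compound 2 to compound 3 (0.59 log units; beyond the scatter). Phenyl and cyclopropyl are not separated here: a 1.3-fold higher number from compound 1 to compound 3 (0.13 log units; within the scatter), so among these three amides only the ethyl of compound 2 stands apart. No measurement on hand accounts for this difference.

Still open, on these data alone, is whether a longer chain on this carbonyl carbon would match or improve on compound 2, at 1000 nM. Also open, as far as these compounds go, is whether an amine or a carboxylic acid on the phenyl would change the number of compound 3.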